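The compounds below may be only part of what the source reports. "The series", "measured", "known", "first", "only" and "open" are said of these compounds alone.

Compound 1 `COc1ccc(C[C@H]2C(=O)N[C@@H](C)C(=O)N(C)[C@H]3Cc4cccc(c4)Oc4cc(ccc4O[C@H]4O[C@H](CO)[C@@H](O)[C@H](O)[C@H]4O)C[C@H](C(=O)N[C@H](C)C(=O)N[C@@H](C)C(=O)N2C)N(C)C3=O)cc1`: 1340 nM
Compound 2 `c1cc(N2CCCCC2)nc(Nc2ccc(Oc3ncnc4sccc34)cc2)n1`: 4020 nM
Compound 3 `CN(c1ccc(Oc2ncnc3ccsc23)cc1)c1nccc(N2CCCCC2)n1`: 8240 nM

All three numbers come from a functional assay on A549 cells (Homo sapiens) for inhibition, read by MTT assay, with a stated time of 72 h; a higher number here means a weaker inhibitor, a lower number a stronger inhibitor. Among them, compound 1 has the lowest number: compound 2 sits above it by a gap beyond the usual scatter, and compound 3 further still. Compounds 2 and 3 are built on a different core from compound 1, so these two values show only how wide the range of the three numbers is, not what any single change to compound 1 does.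

Compound 4 `COc1ccc(C[C@H]2C(=O)N[C@@H](C)C(=O)N(C)[C@H]3Cc4cccc(c4)Oc4cc(ccc4O)C[C@H](C(=O)N[C@H](C)C(=O)N[C@@H](C)C(=O)N2C)N(C)C3=O)cc1` has not yet been measured in this assay. It differs from compound 1 in one place: hydrogen in place of 3,4,5-trihydroxy-6-(hydroxymethyl)oxan-2-yl on an oxygen on an aromatic ring. Going by the values given here, no pair of measured compounds differs in just one place, so there is no measured step to lean on, and the expectation rests on compound 1 alone. Removing a large sugar group and leaving a bare hydroxy is a sizeable change to the outside of the core, and a move toward a lower number is expected, by a step beyond the scatter but not a very large one: the expected step is a 4.5-fold lower number from compound 1 to compound 4 (0.65 log units; beyond the scatter). Compound 4 is therefore estimated to give 300 nM in this assay, with a range from 60 nM to 1500 nM.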

Compound 4, half-maximal inhibitory concentration: 20 nM
Estimate against measurement, compound 4: 15-fold (1.18 log units) above; the measured number lies below the stated range.
By their numbers in this assay, from the lowest: compound 4; then compound 1; then compound 2; then compound 3.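

Taking the 3,4,5-trihydroxy-6-(hydroxymethyl)oxan-2-yl group off the oxygen on the aromatic ring and leaving hydrogen in its place gives a 67-fold lower number from compound 1 to compound 4 (1.83 log units; beyond the scatter) in this assay and this is the first change in the set whose effect can be read on its own, as compound 2 and compound 3 sit on a different core. The step is large and beyond the scatter, so what sits on this oxygen strongly affects the number, and the sugar group is not needed for activity in this cell assay, since the compound with the bare hydroxy has the lower number. Nothing available here explains why removing the sugar has so large an effect.

With only the sugar and hydrogen shown at this oxygen, it remains open whether any group placed there raises the number or only a group like this sugar does, and a methyl ether or an acetyl ester at the same place would help to separate the two. This single pair also leaves open whether the free hydroxy itself contributes to the low number or simply marks the absence of the sugar.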